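Swapping a pyridyl ether: from compound 2 to compound 3

The source may hold more compounds than are shown below. What is called first, only, known or untested is meant among the compounds shown, and "the series" means these compounds.

Two compounds share a core and differ only in the pyridyl ring hung on an aromatic oxygen. Compound 1 `Cc1cccnc1Oc1ccc2nc(COc3cccc(C(=O)O)c3)n(C)c2c1` gives 37 ug/mL in a physicochemical assay for solubility, read by HPLC, measured as thermodynamic solubility, with a stated time of 4 h, at pH 6.8 (a lower number here means a less soluble compound, a higher number a more soluble compound), and compound 2 `Cn1c(COc2cccc(C(=O)O)c2)nc2ccc(Oc3ncccc3F)cc21` gives 7.1 ug/mL in this assay. Going by the values given here, compound 2 stands at the lower of the two numbers; the one measured step, a 5.2-fold lower number from compound 1 to compound 2 (0.72 log units; beyond the scatter), separates them.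

Compound 3 `Cc1cc(Cl)cnc1Oc1ccc2nc(COc3cccc(C(=O)O)c3)n(C)c2c1` is not yet measured. Compared with compound 2 the change is 5-chloro-3-methylpyridin-2-yl in place of 3-fluoropyridin-2-yl on an oxygen on an aromatic ring. Among the compounds with values here, this reverses the fluoro-for-methyl exchange of the measured step and, in addition, places a chloro on the ring; no measured step covers that chloro. The reversed exchange alone, judged from compound 1 at 37 ug/mL against compound 2 at 7.1 ug/mL, would point toward a higher number, while the extra chloro is an open question on these data.

Balancing the two, the expected result is a modest rise, a 1.7-fold higher number from compound 2 to compound 3 (0.23 log units; within the scatter), and compound 3 is estimated at 12 ug/mL in this assay, with a likely range from 3 ug/mL to 40 ug/mL.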

Compound 3, solubility: 3.9 ug/mL
The estimate for compound 3 lay 3.1-fold (0.49 log units) above the measured number; measured number inside the range.
By their numbers in this assay, from the lowest: compounds 3 and 2 (each within the scatter of the next); then compound 1.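

The chloro now has a measured step of its own: with the methyl kept, chloro in place of hydrogen on an aromatic carbon gives a 9.5-fold lower number from compound 1 to compound 3 (0.98 log units; beyond the scatter) in this assay, so this ring does not tolerate every added group without a change in the number. Exchanging 3-fluoropyridin-2-yl for 5-chloro-3-methylpyridin-2-yl on an oxygen on an aromatic ring gives a 1.8-fold lower number from compound 2 to compound 3 (0.26 log units; within the scatter), which leaves compound 2 and compound 3 indistinguishable in this assay even though their rings carry different groups. Two different edits of the ring of compound 1, the fluoro for methyl exchange and the added chloro, thus both end at numbers clearly apart from compound 1, and nothing shown here explains why.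

Going by these compounds, whether this belongs to the chloro itself or would follow any group at that carbon stays open, since an amine or a methoxy group in its place would be needed to tell the two apart. On these data alone, it is equally open what a chloro would do on the 3-fluoropyridin-2-yl ring of compound 2, where the methyl is absent.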